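Trifluoromethoxy for Trifluoromethyl: What to Expect of Compound 4

The compounds below may be only part of what the source reports. "The series", "measured", "known", "first", "only" and "open" are said of these compounds alone.

Compound 3 `O=C(Nc1ccc(C(F)(F)F)cc1)N1CCN(c2nncc3ccccc23)CC1` has been tested in an assay on HEK293 cells for inhibition of transient receptor potential cation channel subfamily V member 1 (Homo sapiens), read by FLIPR (on this read-out lower numbers stand for stronger inhibition and higher numbers for weaker inhibition), and gives only a limit there, > 10000 nM. Compound 1 `Cc1ccc(N2CCN(C(=O)Nc3ccc(OC(F)(F)F)cc3)CC2)nn1` likewise returns a limit in this assay, > 10000 nM. Compound 2 `Cc1cnnc(N2CCN(C(=O)Nc3ccc(OC(F)(F)F)cc3)CC2)c1` also returns a limit, > 10000 nM. Going by the values given here, the step from compound 1 to compound 2 is a step that the two limits leave unreadable from compound 1 to compound 2; (the limit of > 10000 nM in this assay, at which 3 of the 3 values shown sit), so no measured step has a readable size. Compound 4 `O=C(Nc1ccc(OC(F)(F)F)cc1)N1CCN(c2nncc3ccccc23)CC1` differs from compound 3 by trifluoromethoxy in place of trifluoromethyl on an aromatic carbon. Among the compounds with values here, no measured step bears directly on this change; compounds 1 and 2 carry trifluoromethoxy and neither gives a number in this assay. Compound 4 is therefore expected to show no step beyond the scatter, a step that the limit leaves unreadable from compound 3 to compound 4, and most likely another limit. The estimate for compound 4 is 15000 nM, ranging from 4000 nM to 60000 nM.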

Compound 4, half-maximal inhibitory concentration: > 10000 nM
Compound 4 ended at the assay's limit (the forecaster's own chance of this, stated with the estimate: 80%); the middle value is on the limit's open side.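

Compound 4 gives only a limit, so no new step to it can be read from compound 1, compound 2 or compound 3: the limit of > 10000 nM in this assay, at which 4 of the 4 values shown sit.

The compounds shown leave open how trifluoromethoxy and trifluoromethyl compare in this assay, and how far any of the four compounds lies from that limit.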